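A few compounds are considered here, and "the series" means these few. Any claim that something is new, unique, unknown or untested is made for them only; others in the source may bear on it.

In a functional assay on A2780 cells (Homo sapiens) for antiproliferative activity, read by resazurin assay, with a stated time of 72 h (a higher number here means a weaker inhibitor, a lower number a stronger inhibitor), compound 1 (`CN(Cc1ccccc1)C(=O)c1cc2c(Cc3ccccc3)n[nH]c2cc1O`) gives 980 nM and compound 2 (`CN(Cc1ccccc1F)C(=O)c1cc2c(Cc3ccccc3)n[nH]c2cc1O`) gives 1500 nM as measured numbers. Compound 3 (`Cc1cccc(Cc2n[nH]c3cc(O)c(C(=O)NCc4ccccc4)cc23)c1`) reads > 10000 nM in the same test, and this is a limit, not a number.

Compound 4 (`Cc1cccc(Cc2n[nH]c3cc(O)c(C(=O)N(C)Cc4cccc(F)c4)cc23)c1`) differs from compound 3 by (3-fluorobenzyl)(methyl)amino in place of benzylamino on a carbonyl carbon. Going by the values given here, one measured step bears on this: fluoro in place of hydrogen on an aromatic carbon gave a 1.5-fold higher number from compound 1 to compound 2 (0.18 log units; within the scatter) and so stayed within the scatter. Among the compounds with values here, the fluoro is therefore expected to matter little, and no measured step covers the rest of the change.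

Compound 4 is nevertheless expected to resemble compound 2 at 1500 nM more than it resembles compound 3, which means a large step toward a lower number in this assay and a stronger inhibitor. The estimated step is an at least 5.5-fold lower number from compound 3 to compound 4 (0.74 log units; beyond the scatter) on this reading. For compound 4 the expected value is 1800 nM (estimated range 500 nM to 7000 nM).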

Compound 4, half-maximal inhibitory concentration: 440 nM
Estimate against measurement, compound 4: 4.1-fold (0.61 log units) above, outside the stated range (below it).
By their numbers in this assay, from the lowest: compound 4; then compounds 1 and 2 (each within the scatter of the next). At a limit, above all of these: compound 3.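

In this assay, (3-fluorobenzyl)(methyl)amino in place of benzylamino on a carbonyl carbon gives an at least 22-fold lower number from compound 3 to compound 4 (1.35 log units; beyond the scatter) and so shows that this one place on the amide can move the number a long way. Going by these compounds alone, the only earlier change in one place, fluoro in place of hydrogen on an aromatic carbon, gave a 1.5-fold higher number from compound 1 to compound 2 (0.18 log units; within the scatter) and offered no hint of a step this large. Compound 3 reads > 10000 nM and this is a limit, not a number: the limit of > 10000 nM in this assay, at which 1 of the 4 values shown sits.

Going by these compounds, the change brings in a methyl in place of the amide hydrogen and a fluoro on the benzyl ring together, so how much of the step belongs to each stays open. Also open, on these data alone, is whether an ethyl group in place of that methyl, or a carboxylic acid in place of that fluoro, would keep the number this low.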